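A few compounds are considered here, and "the series" means these few. Any claim that something is new, unique, unknown or untested is made for them only; others in the source may bear on it.

Of the compounds shown here, three built on one shared core have so far been tested in a functional assay on the whole organism with Mus musculus as the target, at a dose of 100 mg/kg by the intraperitoneal route; on this read-out lower numbers stand for less inhibition and higher numbers for more inhibition at the one dose given (going by the name of the read-out). Compound 3 `CCN(C)C(=O)/C=C1\CCc2ccc(F)cc21` stands highest of the three, giving 100% in this assay. Compound 1 `O=C(/C=C1\CCc2ccc(F)cc21)NCC1CC1` gives 50%, and compound 2 `O=C(/C=C1\CCc2ccc(F)cc21)N1CCCC1` gives 33%. Both steps up to compound 3 lie beyond the scatter: the rise a number 50 percentage points higher from compound 1 to compound 3 (beyond the scatter) and the larger rise a number 67 percentage points higher from compound 2 to compound 3 (beyond the scatter). The drop a number 17 percentage points lower from compound 1 to compound 2 (beyond the scatter), between the two compounds with the lower numbers, is also beyond the scatter.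

Compound 4 `CCCNC(=O)/C=C1\CCc2ccc(F)cc21` has not yet been measured. It differs from compound 3 in one place: propylamino in place of ethyl(methyl)amino on a carbonyl carbon. The group that leaves carries no hydrogen-bond donor, while the group that enters carries one, as the (cyclopropylmethyl)amino group of compound 1 does.

Going by the values given here, the step that bears most directly on this change is the one from compound 1 to compound 3, where adding the ethyl(methyl)amino group in place of a group with one hydrogen-bond donor gave a number 50 percentage points higher from compound 1 to compound 3 (beyond the scatter). Reversing that kind of change is therefore expected to lower the read-out in this assay, though compound 2 warns that the pattern is not tidy, since its group without a donor gave the lowest number. For compound 4 the expected step is a number 40 percentage points lower from compound 3 to compound 4 (beyond the scatter). Compound 4 is estimated to give about 60% in this assay, within a range from 30% to 95%.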

Compound 4, a percentage reported as inhibition, in the whole organism at one dose (the size of the read-out at that dose, not a potency): 100%
Estimate against measurement, compound 4: 40 percentage points below; the measured number lies above the stated range.
By their numbers in this assay, from the lowest: compound 2; then compound 1; then compounds 3 and 4 (each within the scatter of the next).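

In this assay, going by these compounds alone, propylamino in place of ethyl(methyl)amino on the carbonyl carbon gives no change at the digits printed from compound 3 to compound 4 (within the scatter), so at this position a group carrying a hydrogen-bond donor is compatible with the top number seen here, which the earlier compounds could not show. The donor count does not sort these compounds: ethyl in place of cyclopropyl, a change on the saturated chain carbon bound to the amide-type nitrogen that leaves the donor in place, gives a number 50 percentage points higher from compound 1 to compound 4 (beyond the scatter), while propylamino in place of pyrrolidin-1-yl gives a number 67 percentage points higher from compound 2 to compound 4 (beyond the scatter), and compound 2, without a donor, stands lowest while compound 3, also without one, stands with compound 4 at the top. What lies behind these differences cannot be said, as no measurement of any property of these groups is at hand to explain them.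

Going by these compounds, whether a longer chain such as butylamino, or a chain ending in a carboxylic acid, would keep the number this high remains open. With compound 4 giving 100% at the single dose, as compound 3 does, these results also cannot tell whether the two would still match at lower doses.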